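Compound 4 against compound 3 in the paw edema series

This account rests on a few compounds, and the source may have more. Where it says the series, first, only, none or still open, it means among the compounds named here.

Compound 1 `COc1ccc(C2SCC(=O)N2n2c(CSc3nnc(-c4ccncc4)o3)nc3ccccc3c2=O)cc1` gives 33.8% in a functional assay on the whole organism (strain Charles-Foster albino) for inhibition, with Rattus norvegicus as the target, read by paw edema, at a dose of 50 mg/kg by the oral route; a lower number here means less inhibition, a higher number more inhibition at the dose given (going by the name of the read-out). Compound 2 `COc1ccc(C2SCC(=O)N2n2c(CSc3nnc(-c4ccncc4)o3)nc3ccc(Br)cc3c2=O)cc1` gives 35.3%, and compound 3 `O=C1CSC(c2ccccc2)N1n1c(CSc2nnc(-c3ccncc3)o2)nc2ccccc2c1=O` gives 30.1%. Compound 3 thus holds the lowest of the three numbers, but its gaps to compound 1 and to compound 2 both fall within the scatter. Compound 4 `COc1ccc(/C=N/n2c(CSc3nnc(-c4ccncc4)o3)nc3ccccc3c2=O)cc1` differs from compound 3 by a group of 10 heavy atoms (8 carbon, 1 nitrogen, 1 oxygen; one six-membered aromatic ring of carbon only) in place of a group of 12 heavy atoms (9 carbon, 1 nitrogen, 1 oxygen, 1 sulfur; one five-membered non-aromatic ring with 2 hetero atoms, one six-membered aromatic ring of carbon only), on an aromatic nitrogen. For the measured compounds named here, the two steps measured so far, a number 1.5 percentage points higher from compound 1 to compound 2 (within the scatter) and a number 3.7 percentage points lower from compound 1 to compound 3 (within the scatter), each exchange a group on an aromatic carbon and both stay within the scatter; neither touches the group on the aromatic nitrogen, so no step of the present kind has been measured. With nothing pointing either way, the step of a number 0.9 percentage points higher from compound 3 to compound 4 (within the scatter) is expected to stay within the scatter. Compound 4 is therefore estimated at 31%, with a range of 20% to 42%.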

Compound 4, a percentage reported as inhibition, in the whole organism at one dose (the size of the read-out at that dose, not a potency): 20%
Estimate against measurement, compound 4: 11 percentage points above; the range from low to high includes it.
By their numbers in this assay, from the lowest: compound 4; then compounds 3, 1 and 2 (each within the scatter of the next).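

On the aromatic nitrogen of the shared core, replacing 4-oxo-2-phenyl-1,3-thiazolidin-3-yl gives, in this assay, a step of a number 10.1 percentage points lower from compound 3 to compound 4 (beyond the scatter) and the only one so far beyond the scatter. For the compounds shown here, the two steps on aromatic carbons stayed within it, so this position is the first to respond. No measurement available bears on the reason for this step.

The compounds shown leave open how a smaller group on this nitrogen, such as a plain amine, would read. Also open, on these data alone, is whether a carboxylic acid on the aromatic ring of this group would alter the result.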